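The compounds below may be only part of what the source reports. "The series", "measured", "known", "first", "only" and "open" are said of these compounds alone.

Of the compounds shown here, three have been measured in a functional assay on KYSE-450 cells (Homo sapiens) for inhibition, read by MTT assay, with a stated time of 48 h; on this read-out lower numbers stand for stronger inhibition and higher numbers for weaker inhibition. Compound 1 `C/C=C/C(=O)N(Cc1cccc(O)c1)c1cc(OC)c(OC)c(OC)c1` gives 14700 nM in this assay, while compound 3 `COC(=O)c1cc(CNc2cc(OC)c(OC)c(OC)c2)ccc1OC` gives 41100 nM. Compound 2 `COc1ccc(CN(C(=O)CCl)c2cc(OC)c(OC)c(OC)c2)cc1O` gives 210 nM in this assay, the lowest of the three numbers: compound 1 sits at a higher number that lies beyond the scatter, and compound 3 sits higher still, also beyond the scatter. Compound 2 is therefore the most potent of the three on the numbers shown.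

Compound 4 `COc1ccc(CN(C(=O)CCCCCl)c2cc(OC)c(OC)c(OC)c2)cc1O` has not yet been measured in this assay. It differs from compound 2 in one place: 3-chloropropyl in place of chloro on a saturated chain carbon bound to a carbonyl carbon. The chloroacetamide of compound 2 becomes a (4-chlorobutyl)carbonyl amide in compound 4.

Within the data shown here, no single-change step between measured compounds is available to calibrate this change. Compound 1, one of the two compounds without the chloromethyl-carbonyl group, gives 14700 nM, and compound 3, the other, gives 41100 nM. Both are far weaker than compound 2. The expected step is therefore a large loss, with the step from compound 2 to compound 4 estimated at a 71-fold higher number from compound 2 to compound 4 (1.85 log units; beyond the scatter). Compound 4 is expected to give about 15000 nM in this assay, with a range from 3000 nM to 60000 nM.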

Compound 4, half-maximal inhibitory concentration: 770 nM
Beside the measured number, compound 4's estimate is 19-fold (1.29 log units) above it, outside the stated range (below it).
By their numbers in this assay, from the lowest: compound 2; then compound 4; then compound 1; then compound 3.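

In this assay the change from chloromethyl to 4-chlorobutyl on the carbonyl gives a 3.7-fold higher number from compound 2 to compound 4 (0.56 log units; beyond the scatter) and so costs a modest amount, though a step beyond the usual scatter. Among these compounds, this is the first single-change step at this position, which the earlier compounds could not provide, and it shows that the chlorine need not stay on the saturated chain carbon bound to a carbonyl carbon for the loss to remain modest. Nothing shown here accounts for the size of this step.

The compounds shown leave open how the number moves with chain length, since 2-chloroethyl and 3-chloropropyl on the carbonyl, the chains of intermediate length, and chains longer than 4-chlorobutyl do not appear among them. They also leave open whether the chlorine at the end of the chain matters at all, which a plain butyl chain, or a 4-hydroxybutyl or 4-bromobutyl group in the same place, would test directly in this assay.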